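A Carbamate in Place of a Benzamide on a Shared Core

The compounds below may be only part of what the source reports. "The series", "measured", "known", "first", "only" and "open" are said of these compounds alone.

Compound 1 `CCN(CC)c1cc2[nH]c(C3CCCCC3)nc2cc1NC(=O)c1ccc(N(C)C)cc1` — in an ADME assay on Vero cells (Chlorocebus sabaeus) for cytotoxicity, read by resazurin assay, with a stated time of 3 days (on this read-out higher numbers stand for weaker inhibition and lower numbers for stronger inhibition), compound 1 gives "not determined" (no result reported), so no result is available for it.
Compound 2 `CCN(CC)c1cc2[nH]c(C3CCCCC3)nc2cc1NC(=O)c1ccc(C)cc1` — in this assay compound 2 gives > 100 ug/mL, which is a limit of the assay and not a number.

For the measured compounds named here, compound 2 therefore stands only at the limit of > 100 ug/mL in this assay, at which 1 of the 2 values shown sits; with compound 1 lacking a result, no step between measured compounds can be drawn, and nothing measured tells how large a change of this kind would be.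

Compound 3 `CCOCCOC(=O)Nc1cc2nc(C3CCCCC3)[nH]c2cc1N(CC)CC` differs from compound 2 by 2-ethoxyethoxy in place of 4-methylphenyl on a carbonyl carbon.

Since compound 2 reaches only a limit, the writer expects the step of a number no higher from compound 2 to compound 3 (the limit leaves the size open) to be none beyond the scatter, with a fair chance that compound 3 again yields only a limit. Compound 3 is accordingly estimated at 100 ug/mL, within a range from 40 ug/mL to 200 ug/mL.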

Compound 3, half-maximal inhibitory concentration: > 100 ug/mL
Compound 3: a limit, no number; the forecaster's own chance of this, stated with the estimate: 70%; the middle value sits exactly at the limit.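

In this assay compound 3 gives > 100 ug/mL, a limit of the assay and not a number. For the compounds shown here, compound 2 also stands at a limit, so no step between compound 2 and compound 3 can be read. The compounds shown leave open what size of change, if any, 2-ethoxyethoxy in place of 4-methylphenyl on a carbonyl carbon brings.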